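The compounds below may be only part of what the source reports. "The series", "measured", "known", "first", "only" and "open" are said of these compounds alone.

Measured compounds:
compound 1 `CC(C)(C)N(NC(=O)c1ccccc1)C(=O)c1ccccc1Cl` — 75.9 nM
compound 2 `CC(C)(C)N(NC(=O)c1ccc(C#N)cc1)C(=O)c1ccccc1Cl` — 603 nM

In an assay on cells for agonist activity at ecdysone receptor (Bombyx mori), read by a luciferase reporter, with a stated time of 24 h (on this read-out lower numbers stand for an effect already at smaller amounts and higher numbers for an effect only at larger amounts of compound), compound 2 gives the highest of the two numbers, its nearest neighbour being compound 1 at 75.9 nM. For the measured compounds named here, the single step between them, a 7.9-fold higher number from compound 1 to compound 2 (0.90 log units; beyond the scatter), lies beyond the scatter and is the only measured step available. Compound 3 `Cc1ccc(C(=O)NN(C(=O)c2ccccc2Cl)C(C)(C)C)cc1` differs from compound 2 by methyl in place of cyano on an aromatic carbon. Going by the values given here, no measured step covers a methyl at that position, so the change is judged from the cyano step alone: it undoes the cyano, which brought the higher number, and puts in a methyl whose own effect is unknown. The expected result is a return toward the number of compound 1, with a wide range, and for compound 3 the estimate is 80 nM (25 nM to 300 nM), a step of a 7.5-fold lower number from compound 2 to compound 3 (0.88 log units; beyond the scatter).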

Compound 3, half-maximal effective concentration: 18.6 nM
For compound 3 the middle estimate is 4.3-fold (0.63 log units) above the measured one; measured number outside the range, below it.
By their numbers in this assay, from the lowest: compound 3; then compound 1; then compound 2.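

In this assay, the place para to a large group turns out to accept a substituent with a gain rather than a loss: methyl in place of hydrogen gives a 4.1-fold lower number from compound 1 to compound 3 (0.61 log units; beyond the scatter), whereas the earlier cyano had raised the number. Methyl in place of cyano gives a 32-fold lower number from compound 2 to compound 3 (1.51 log units; beyond the scatter), so the two groups move the number in opposite directions from hydrogen, and the cost seen with cyano does not extend to every group at this place. Nothing available here accounts for this difference between the two groups. The compounds shown leave open whether an ethyl group, a methoxy group or an amine at this place would follow methyl or cyano. They also leave open whether the gain from methyl persists when another part of the shared core changes.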